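The source may hold more compounds than are shown below. What is called first, only, known or untested is meant among the compounds shown, and "the series" means these compounds.

Compound 1, `CC(=O)c1nc([N+](=O)[O-])c(Sc2c(Cl)cncc2Cl)s1`, gives 670 nM in an assay on isolated protein for inhibition of ubiquitin carboxyl-terminal hydrolase 7 (Homo sapiens), read by fluorescence, with stated times of 30 min and 3 h; a higher number here means a weaker inhibitor, a lower number a stronger inhibitor. Compound 3, `Cc1ccc(CNC(=O)c2nc([N+](=O)[O-])c(Sc3c(Cl)cncc3Cl)s2)cc1`, gives 3650 nM in this assay. Compound 2, `COc1cccc(Sc2sc(C(C)=O)nc2[N+](=O)[O-])c1`, is reported in this assay only as a limit, > 50000 nM; this is the limit of > 50000 nM in this assay, at which 1 of the 3 values shown sits. Of the two numbers in hand, compound 3 holds the higher one, the step being a 5.4-fold higher number from compound 1 to compound 3 (0.74 log units; beyond the scatter), which put (4-methylbenzyl)amino in place of methyl on a carbonyl carbon.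

Compound 4, `O=C(NCc1ccccc1)c1nc([N+](=O)[O-])c(Sc2c(Cl)cncc2Cl)s1`, differs from compound 3 by hydrogen in place of methyl on an aromatic carbon. Going by the values given here, the only measured step concerns the carbonyl substituent, not the aromatic ring, so no measured step bears directly on this change; a group with one heavy atom and no ring leaves and a hydrogen enters. Compound 4 is therefore expected to sit close to compound 3 in this assay, with a step of a 1.0-fold higher number from compound 3 to compound 4 (0.01 log units; within the scatter) that lies within the scatter. The estimate for compound 4 in this assay is 3700 nM, with a range from 1500 nM to 9000 nM.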

Compound 4, half-maximal inhibitory concentration: 4210 nM
For compound 4 the middle estimate is 1.1-fold (0.06 log units) below the measured one; measured number inside the range.
By their numbers in this assay, from the lowest: compound 1; then compounds 3 and 4 (each within the scatter of the next). At a limit, above all of these: compound 2.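

In this assay, taking the methyl off the aromatic ring of the 4-methylbenzyl group gives a 1.2-fold higher number from compound 3 to compound 4 (0.06 log units; within the scatter) and so, at this place on the ring, methyl and hydrogen cannot be told apart. With benzylamino in place of methyl on the carbonyl carbon the record reads a 6.3-fold higher number from compound 1 to compound 4 (0.80 log units; beyond the scatter) and so the rise seen on moving to the amide does not depend on the ring methyl. Nothing in the data on hand bears on why these numbers fall as they do.

Still open, on these data alone, is whether a larger group at this place on the ring, such as methoxy, chlorine or a carboxylic acid, would move the number at all. Also open, as far as these compounds go, is whether a phenethyl amide or an amide carrying a simple amine on a longer chain would come closer to compound 1 at 670 nM.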